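Aryl methyl for ethoxy on the chloro core

A few compounds are considered here, and "the series" means these few. Any claim that something is new, unique, unknown or untested is made for them only; others in the source may bear on it.

Of the compounds shown here, three have been measured in an assay on HL-60 cells for inhibition of glutathione S-transferase P (Homo sapiens), read by spectrophotometry, tested at 20 uM; a lower number here means less inhibition, a higher number more inhibition at the concentration tested (going by the name of the read-out). Compound 1 `CCOc1ccc(/C=C2\CN(CC(=O)O)c3c(C)cccc3C2=O)cc1` gives 42.4%. Compound 2 `Cc1ccc(/C=C2\CN(CC(=O)O)c3c(C)cccc3C2=O)cc1` gives 46.8%. Compound 3 `CCOc1ccc(/C=C2\CN(CC(=O)O)c3c(Cl)cccc3C2=O)cc1` gives 59.1%, the highest of the three, and its steps to both others are beyond the scatter.

The change from compound 1 to compound 2 is methyl in place of ethoxy on an aromatic carbon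
and it made a step of a number 4.4 percentage points higher from compound 1 to compound 2 (within the scatter), so the two numbers cannot be ordered. The two cores differ as chloro in place of methyl on an aromatic carbon
and that change made a step of a number 16.7 percentage points higher from compound 1 to compound 3 (beyond the scatter).

Compound 4 `Cc1ccc(/C=C2\CN(CC(=O)O)c3c(Cl)cccc3C2=O)cc1` has not been measured. It differs from compound 3 as methyl in place of ethoxy on an aromatic carbon
The place line reads the same, word for word, as for the change from compound 1 to compound 2, so it is the same change, now made on the core of compound 3. For the measured compounds named here, the change occurs twice in all; its one measured instance is the step from compound 1 to compound 2. Compound 4 is therefore expected to land a step of a number 3.9 percentage points higher from compound 3 to compound 4 (within the scatter) from compound 3, kept within the scatter because the earlier instance gave a number 4.4 percentage points higher from compound 1 to compound 2 (within the scatter). Going by the values given here, with only one prior instance, on a different core, the spread around that expectation is wide. Compound 4 is estimated at 63% in this assay, with the range 50% to 76%.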

Compound 4, a percentage reported as inhibition, at one concentration (the size of the read-out at that concentration, not a potency): 67.6%
Compound 4: the middle estimate sits 4.6 percentage points below what was measured, within the range that was stated.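

In this assay, methyl in place of ethoxy on an aromatic carbon, now on the chloro core, gives a number 8.5 percentage points higher from compound 3 to compound 4 (within the scatter), and the step agrees with the one on the methyl core: the same change on two cores in this assay, a number 4.4 percentage points higher (within the scatter) from compound 1 to compound 2 and a number 8.5 percentage points higher (within the scatter) from compound 3 to compound 4, 4.1 percentage points apart, within the scatter of two such steps

Chloro in place of methyl on an aromatic carbon, now with methyl in place of ethoxy, gives a number 20.8 percentage points higher from compound 2 to compound 4 (beyond the scatter), so this change also carries from one core to the other: the same change on two cores in this assay, a number 16.7 percentage points higher (beyond the scatter) from compound 1 to compound 3 and a number 20.8 percentage points higher (beyond the scatter) from compound 2 to compound 4, 4.1 percentage points apart, within the scatter of two such steps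

This shows that, across these four compounds, each change gives a similar step on both backgrounds, with the chloro change the only one beyond the scatter; it does not show that methyl in place of ethoxy has any effect on either core, and two cores are too few to show that the agreement extends to others in the series.

Still open, going by these compounds, is how an amine, a nitrile or a longer alkoxy chain would read on the aromatic carbon that carries ethoxy or methyl here, and how bromo or trifluoromethyl would compare with chloro on the core. Also open, on these data alone, are the effect of replacing the carboxylic acid shared by all four compounds with an ester or an amide, and how these readings at one concentration relate to potency.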